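Acetamido Substitution on a Biaryl Ether Scaffold

The compounds below may be only part of what the source reports. "The series", "measured", "known", "first", "only" and "open" are said of these compounds alone.

The study concerns an assay on COS-7 cells for inhibition of patatin-like phospholipase domain-containing protein 2 (Mus musculus), tested at 200 uM; on this read-out lower numbers stand for less inhibition and higher numbers for more inhibition at the one concentration tested (going by the name of the read-out). Compound 1, with the structure `CCOC(=O)c1cccc(-c2ccc(C(C)N(C)C)cc2)c1`, reaches 50% in this assay. Compound 2, with the structure `CCOc1ccc(-c2ccccc2)cc1`, gives 35%, the lowest of the two numbers shown, and the nearest measured compound is compound 1, which stands higher by an amount beyond the usual scatter.

Compound 3, with the structure `CCOc1ccc(-c2cccc(NC(C)=O)c2)cc1`, has not yet been measured. It differs from compound 2 as follows: acetamido in place of hydrogen on an aromatic carbon. The new group enters on an aromatic carbon of a six-membered aromatic ring of carbon only, meta to a group of nine heavy atoms.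

Within the data shown here, no pair of measured compounds that differ in one place is available, so the size of the step from compound 2 to compound 3 is uncertain. Compound 1, carrying extra groups on its core, gives 50%, and on that basis the step is expected to be a modest rise, estimated as a number 10 percentage points higher from compound 2 to compound 3 (within the scatter). Compound 3 is expected to give 45%, with a range from 25% to 65%.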

Compound 3, a percentage reported as inhibition, at one concentration (the size of the read-out at that concentration, not a potency): 52%
Beside the measured number, compound 3's estimate is 7 percentage points below it; the range from low to high includes it.
By their numbers in this assay, from the lowest: compound 2; then compounds 1 and 3 (each within the scatter of the next).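

In this assay acetamido in place of hydrogen on an aromatic carbon, meta to a group of 9 heavy atoms, goes with a number 17 percentage points higher from compound 2 to compound 3 (beyond the scatter) and gives the first step read between two compounds that differ in one place. It shows that this aromatic carbon can carry a substituent without any loss of inhibition at the one concentration tested, and that this particular change, which brings in one hydrogen-bond donor and one hydrogen-bond acceptor, raises the read-out by more than repeated measurements would scatter. No measured evidence bears on the origin of this step.

The compounds shown leave open whether a plain amine, a carboxylic acid or a methoxy group on the same carbon would give a similar rise. They also leave open what a longer chain such as propionamido, or acetamido on another carbon of that ring, would give.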